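Effect of a third methoxy on paw edema inhibition

The source may hold more compounds than are shown below. What is called first, only, known or untested is meant among the compounds shown, and "the series" means these compounds.

Measured compounds in a functional assay on the whole organism (strain albino) for inhibition, with Rattus norvegicus as the target, read by paw edema, with stated times of 30 min and 2 h, at a dose of 0.28 mmol/kg by the oral route; a lower number here means less inhibition, a higher number more inhibition at the dose given (going by the name of the read-out):
Compound 1 `CCn1c(SCC(=O)Nc2ccc(/C(C)=N/O)cc2)nnc1-c1ccc(OC)c(OC)c1` — compound 1 gives 65%
Compound 2 `CCn1c(SCC(=O)Nc2ccc(/C(C)=N/O)cc2)nnc1-c1cc(OC)c(OC)c(OC)c1` — compound 2 gives 49%
Compound 3 `CCn1c(SCC(=O)Nc2ccc(C(C)=O)cc2)nnc1-c1ccc(OC)c(OC)c1` — compound 3 gives 59%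

Compound 3 stands second of the three numbers, yet its gap to compound 1 and its gap to compound 2 both lie within the scatter of repeated measurements, so no ranking among them can be claimed.

Compound 4 `CCn1c(SCC(=O)Nc2ccc(C(C)=O)cc2)nnc1-c1cc(OC)c(OC)c(OC)c1` differs from compound 3 in one place: methoxy in place of hydrogen on an aromatic carbon

The same change has already been measured once, in the pair from compound 1 to compound 2: a number 16 percentage points lower from compound 1 to compound 2 (beyond the scatter). That step ran beyond the scatter. The step from compound 1 to compound 3, a number 6 percentage points lower from compound 1 to compound 3 (within the scatter), shows that the group on the other aromatic ring changed little, so the earlier step is taken as the guide. Compound 4 is therefore expected to fall below compound 3 by a modest amount, a number 16 percentage points lower from compound 3 to compound 4 (beyond the scatter), because of a number 16 percentage points lower from compound 1 to compound 2 (beyond the scatter). The estimate for compound 4 is 43%, with a range from 30% to 56%.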

Compound 4, a percentage reported as inhibition, in the whole organism at one dose (the size of the read-out at that dose, not a potency): 50%
For compound 4 the middle estimate is 7 percentage points below the measured one, and the stated range covers the measured number.
By their numbers in this assay, from the lowest: compounds 2, 4, 3 and 1 (each within the scatter of the next, the first and the last beyond it).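

In this assay, methoxy in place of hydrogen on this aromatic carbon, ortho to a methoxy group, was now read on a second core and gave a number 9 percentage points lower from compound 3 to compound 4 (within the scatter), so the change did not clear the scatter there as it had on the first core. The two readings of this change point the same way and cannot be told apart in size: the same change on two cores in this assay, a number 16 percentage points lower (beyond the scatter) from compound 1 to compound 2 and a number 9 percentage points lower (within the scatter) from compound 3 to compound 4, 7 percentage points apart, within the scatter of two such steps

The other exchange, a group of 3 heavy atoms in place of a group of 4 heavy atoms, gave a number 1 percentage points higher from compound 2 to compound 4 (within the scatter), so it made no readable difference on either core: the same change on two cores in this assay, a number 6 percentage points lower (within the scatter) from compound 1 to compound 3 and a number 1 percentage points higher (within the scatter) from compound 2 to compound 4, 7 percentage points apart, within the scatter of two such steps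

As far as these compounds go, it remains open whether methoxy truly lowers inhibition on the second core, and whether these numbers would hold at other doses. From the compounds shown here alone, how an amine, a hydroxyl or a longer chain such as ethoxy would read at this position is also open.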